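Three Fluorines for One at the Aryl Ether

The source may report more compounds than this note shows. Statements on the series, on what has been measured and on what is new or still open speak of the compounds shown alone.

Compound 3, `CC(C)[C@H](NC(=O)COc1cccc2ccccc12)C(=O)N[C@@H](CC(=O)O)C(=O)COc1cccc(F)c1`, carries a 3-fluorophenyl on an oxygen on a saturated carbon. In a functional assay on Jurkat cells (Homo sapiens) (a higher number here means a weaker inhibitor, a lower number a stronger inhibitor), compound 3 gives only a limit of the assay, > 100000 nM. Compound 1, `CC(C)[C@H](NC(=O)COc1cccc2ccccc12)C(=O)N[C@@H](CC(=O)O)C(=O)COc1ccc(OC(F)(F)F)cc1`, gives 29100 nM in this assay. Compound 2, `CC(C)[C@H](NC(=O)COc1cccc2ccccc12)C(=O)N[C@@H](CC(=O)O)C(=O)COc1ccccc1[N+](=O)[O-]`, likewise reaches only a limit in this assay, > 100000 nM. Within the data shown here, the step of an at least 3.4-fold higher number from compound 1 to compound 3 (0.53 log units; beyond the scatter) is the one readable comparison; the step that the two limits leave unreadable from compound 2 to compound 3 cannot be sized because of the limit of > 100000 nM in this assay, at which 2 of the 3 values shown sit.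

Compound 4, `CC(C)[C@H](NC(=O)COc1cccc2ccccc12)C(=O)N[C@@H](CC(=O)O)C(=O)COc1cc(F)cc(F)c1F`, differs from compound 3 by 2,3,5-trifluorophenyl in place of 3-fluorophenyl on an oxygen on a saturated carbon. Among the measured compounds shown here, no measured step exchanges one fluorine for three on this ring, so the expectation rests only on where compound 3 stands, which is at the limit. Compound 4 is therefore expected to sit near that limit as well, with an estimated step of an at least 1.1-fold lower number from compound 3 to compound 4 (0.04 log units; that floor lies within the scatter) and no clear direction. Compound 4 is estimated at 90000 nM, with a range from 25000 nM to 300000 nM, and a real chance that the assay again reports only a limit.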

Compound 4, half-maximal inhibitory concentration: 30000 nM
Compound 4: middle estimate off by 3.0-fold (0.48 log units), on the high side, and the stated range covers the measured number.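

In this assay, this position on the oxygen proves able to respond to a fluorine-only change: going from 3-fluorophenyl to 2,3,5-trifluorophenyl gives an at least 3.3-fold lower number from compound 3 to compound 4 (0.52 log units; beyond the scatter). Exchanging 2-nitrophenyl for the same 2,3,5-trifluorophenyl gives an at least 3.3-fold lower number from compound 2 to compound 4 (0.52 log units; beyond the scatter), so this ring brings the read-out back from the limit of the assay to a measured number. Among these compounds, the comparison with the only other measured number gives a 1.0-fold higher number from compound 1 to compound 4 (0.01 log units; within the scatter), which places 2,3,5-trifluorophenyl level with 4-(trifluoromethoxy)phenyl at this position.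

As far as these compounds go, the true size of the first two steps stays open, and the comparison of compound 2 with compound 3 cannot be read: the limit of > 100000 nM in this assay, at which 2 of the 4 values shown sit. Also open is whether a nitrile or a methoxy group on this ring, or an amine in place of the aryl ether, would go beyond compound 1 and compound 4.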